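Methoxycarbonyl to ethoxycarbonyl on compound 2

The source may hold more compounds than are shown below. What is called first, only, known or untested is meant among the compounds shown, and "the series" means these compounds.

Values in a functional assay, read by spectrophotometry, with a stated time of 10 min (on this read-out lower numbers stand for an effect already at smaller amounts and higher numbers for an effect only at larger amounts of compound), so far:
- compound 1 `COC(=O)C1=C(C)NC(=O)NC1c1ccc(OC)cc1` gives 1.92 ug/mL
- compound 2 `COC(=O)C1=C(C)NC(=O)NC1c1ccc(O)cc1` gives 0.79 ug/mL
- compound 3 `COC(=O)C1=C(C)NC(=O)NC1c1ccccc1` gives 2.23 ug/mL

Compound 2 holds the lowest number of the three. Two modest steps beyond the scatter set it apart: a 2.4-fold lower number from compound 1 to compound 2 (0.39 log units; beyond the scatter) and a 2.8-fold higher number from compound 2 to compound 3 (0.45 log units; beyond the scatter) on the aromatic ring. The remaining step of a 1.2-fold higher number from compound 1 to compound 3 (0.07 log units; within the scatter) stays within the scatter.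

Compound 4 `CCOC(=O)C1=C(C)NC(=O)NC1c1ccc(O)cc1` has not yet been measured. Its difference from compound 2 is methyl in place of hydrogen on a saturated chain carbon bound to an oxygen next to a carbonyl group and reads as methyl in place of hydrogen on a saturated chain carbon bound to an oxygen next to a carbonyl group, or methoxycarbonyl to ethoxycarbonyl.

Among the measured compounds shown here, no measured step touches this place, as all three change a group on the aromatic ring. They serve only as a gauge of size, and the largest of them, a 2.8-fold higher number from compound 2 to compound 3 (0.45 log units; beyond the scatter) is still modest. With the ring group kept as in compound 2 at 0.79 ug/mL no step beyond the scatter is expected, and these data give no direction. In this assay the estimated outcome is a 1.1-fold higher number from compound 2 to compound 4 (0.03 log units; within the scatter) as a working figure. For compound 4 the estimate is 0.85 ug/mL with an expected range from 0.4 ug/mL to 1.7 ug/mL in this series.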

Compound 4, half-maximal effective concentration: 0.89 ug/mL
Compound 4: middle estimate off by 1.0-fold (0.02 log units), on the low side, and the stated range covers the measured number.
By their numbers in this assay, from the lowest: compounds 2 and 4 (each within the scatter of the next); then compounds 1 and 3 (each within the scatter of the next).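

In this assay, among the compounds shown here, the one step at this place is a 1.1-fold higher number from compound 2 to compound 4 (0.05 log units; within the scatter), so with the hydroxy group on the aromatic ring kept, methoxycarbonyl to ethoxycarbonyl leaves the read-out unresolved from that of compound 2. The earlier compounds shown here showed changes only on the aromatic ring, where a 2.4-fold lower number from compound 1 to compound 2 (0.39 log units; beyond the scatter) and a 2.8-fold higher number from compound 2 to compound 3 (0.45 log units; beyond the scatter) both lie beyond the scatter; the methyl added on the saturated chain carbon bound to an oxygen next to a carbonyl group gives no such separation, and the ring group remains the only place in this set with a step beyond the scatter. Nothing available offers a reason for this flat step.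

The compounds shown leave open whether the flat response extends past one added methyl, for instance to a propyl or isopropyl ester, or holds with a different group at this place, such as a carboxylic acid or a primary amide. They also leave open whether ethoxycarbonyl behaves the same way when paired with the methoxy group of compound 1 or the unsubstituted ring of compound 3.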